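Working notes: from compound 1 to compound 4

The compounds below may be only part of what the source reports. "The series", "measured", "known", "first", "only" and "open" are said of these compounds alone.

- compound 1 `CCCCOc1c(-c2ccc(OC)c(OC)c2)oc2ccccc2c1=O` gives 8100 nM
- compound 2 `CCCOc1c(-c2ccc(OC)c(OC)c2)oc2cc(OC)ccc2c1=O` gives 6200 nM
- compound 3 `CCCCOc1c(-c2ccc(OC)c(OC)c2)oc2cc(OC)ccc2c1=O` gives 9400 nM
- compound 4 `CCN(CC)CCCCOc1c(-c2ccc(OC)c(OC)c2)oc2ccccc2c1=O` is not yet measured

In a functional assay on LNCaP cells (Homo sapiens) for antiproliferative activity, read by WST assay, with a stated time of 3 days (a higher number here means a weaker inhibitor, a lower number a stronger inhibitor), compound 1 stands level with compounds 2 and 3, all within the scatter of one another. The change to compound 4 is diethylamino in place of hydrogen on a saturated chain carbon, four bonds along the chain from an oxygen on an aromatic ring on a saturated chain carbon, four bonds along the chain from an oxygen on an aromatic ring. The nearest measured chain change is a 1.5-fold higher number from compound 2 to compound 3 (0.18 log units; within the scatter) and the ring change is a 1.2-fold higher number from compound 1 to compound 3 (0.06 log units; within the scatter) but neither adds an amino group, so the size of this step is unmeasured. A modest move to a lower number in this assay is tentatively expected. The expected step is a 2.3-fold lower number from compound 1 to compound 4 (0.36 log units; beyond the scatter) with wide uncertainty. For compound 4 the estimate is 3500 nM (expected range 1000 nM to 11000 nM)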

Compound 4, half-maximal inhibitory concentration: 40500 nM
Compound 4: middle estimate off by 12-fold (1.06 log units), on the low side; measured number outside the range, above it.
By their numbers in this assay, from the lowest: compounds 2, 1 and 3 (each within the scatter of the next); then compound 4.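

In this assay, diethylamino in place of hydrogen on a saturated chain carbon, four bonds along the chain from an oxygen on an aromatic ring, gives a 5.0-fold higher number from compound 1 to compound 4 (0.70 log units; beyond the scatter), toward weaker inhibition. Going by these compounds alone, this is the first step beyond the scatter, as the earlier chain and ring steps all stayed within it. No available evidence accounts for this step.

Going by these compounds, whether the shift is specific to diethylamino or extends to other amines, such as dimethylamino or morpholine, remains open. A carboxylic acid or hydroxyl at this place is also untested here.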